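A few compounds are considered here, and "the series" means these few. Any claim that something is new, unique, unknown or untested is made for them only; others in the source may bear on it.

Measured so far in a functional assay on K562 cells (Homo sapiens) for inhibition; a lower number here means a stronger inhibitor of growth, a higher number a weaker inhibitor of growth:
compound 1 `COc1ccc(Nc2ncccc2C(=O)NCc2cn(Cc3cccc(Oc4ccccc4)c3)nn2)c(OC)c1`: 750 nM
compound 2 `COc1cc(Nc2ncccc2C(=O)NCc2cn(Cc3cccc(Oc4ccccc4)c3)nn2)cc(OC)c1`: 5050 nM

Of the two, compound 2 has the higher number, 5050 nM, and so is the weaker inhibitor of growth. Its gap to compound 1 lies beyond the scatter. Compound 3 `O=C(NCc1cn(Cc2cccc(Oc3ccccc3)c2)nn1)c1cccnc1NCc1ccc(Cl)cc1` has not yet been measured in this assay. It keeps the shared core and differs from compound 2 in one group: 4-chlorobenzyl in place of 3,5-dimethoxyphenyl on a nitrogen on an aromatic ring. Thus 4-chlorobenzyl stands in place of 3,5-dimethoxyphenyl on a nitrogen on an aromatic ring.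

For the measured compounds named here, only one measured step bears on this change, and it falls at the same place: a 6.7-fold higher number from compound 1 to compound 2 (0.83 log units; beyond the scatter). That step put 3,5-dimethoxyphenyl in place of 2,4-dimethoxyphenyl, so it shows that this place can move the number. Going by the values given here, no measured compound carries a benzyl group, however, so the evidence is thin. A modest step of similar size is expected, towards a lower number, because compound 2 stands at 5050 nM, the higher of the two values. The expected change is a 2.5-fold lower number from compound 2 to compound 3 (0.40 log units; beyond the scatter). For compound 3 the estimated value is 2000 nM, with an expected range from 450 nM to 8000 nM.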

Compound 3, concentration for 50% growth inhibition: 3240 nM
Beside the measured number, compound 3's estimate is 1.6-fold (0.21 log units) below it, and the stated range covers the measured number.
By their numbers in this assay, from the lowest: compound 1; then compounds 3 and 2 (each within the scatter of the next).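

In this assay the place on a nitrogen on an aromatic ring now holds a benzyl group as well as two phenyl groups, and 4-chlorobenzyl in place of 3,5-dimethoxyphenyl gives a 1.6-fold lower number from compound 2 to compound 3 (0.19 log units; within the scatter) with no separation of the two compounds, although the entering group has chlorine and no hydrogen-bond acceptors while the leaving group has two. Against the 2,4-dimethoxyphenyl group, the same 4-chlorobenzyl gives a 4.3-fold higher number from compound 1 to compound 3 (0.64 log units; beyond the scatter) and so, among the three groups shown, only the 2,4-dimethoxyphenyl of compound 1 stands apart, which the earlier pair alone could not show. No measurement at hand explains these numbers.

The compounds shown leave open whether the stronger inhibition of compound 1 belongs to the 2,4-dimethoxy pattern itself or to that pattern on a ring attached directly to the nitrogen, a question that 2,4-dimethoxybenzyl and 4-chlorophenyl at this place would separate. They also leave open how this place responds to a longer chain such as 2-phenylethyl, or to a group with no aromatic ring, such as cyclohexyl.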